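Notes: methoxy to trifluoromethoxy at the assay limit

This account rests on a few compounds, and the source may have more. Where it says the series, first, only, none or still open, it means among the compounds named here.

Values in an ADME assay on MDCK cells (Canis lupus familiaris) for cytotoxicity; on this read-out lower numbers stand for higher toxicity in this test and higher numbers for lower toxicity in this test (each a limit):
- compound 1 `CC(=O)Nc1ccc2oc(-c3ccnc(C(=O)N4CCN(C(c5cccc(F)c5)c5nnn(C)n5)CC4)c3)nc2c1` gives > 50000 nM
- compound 2 `CC(=O)Nc1ccc2oc(-c3ccnc(C(=O)N4CCN(C(c5ccc(Cl)cc5)c5nnn(C)n5)CC4)c3)nc2c1` gives > 50000 nM
- compound 3 `COc1ccc(C(c2nnn(C)n2)N2CCN(C(=O)c3cc(-c4nc5cc(NC(C)=O)ccc5o4)ccn3)CC2)cc1` gives > 50000 nM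

Compound 3 stands at > 50000 nM, which is a limit and not a number. The whole measured set sits at the limit of > 50000 nM in this assay, at which 3 of the 3 values shown sit. Compound 4 `CC(=O)Nc1ccc2oc(-c3ccnc(C(=O)N4CCN(C(c5ccc(OC(F)(F)F)cc5)c5nnn(C)n5)CC4)c3)nc2c1` differs from compound 3 by trifluoromethyl in place of methyl on an oxygen on an aromatic ring. Three measured changes bear on this: a step that the two limits leave unreadable from compound 2 to compound 3, a step that the two limits leave unreadable from compound 1 to compound 3 and a step that the two limits leave unreadable from compound 1 to compound 2. None has a readable size, so no direction can be expected in this assay. The expected step is a number no higher from compound 3 to compound 4 (the limit leaves the size open), with no change beyond the scatter foreseen. For compound 4 the estimated value is 50000 nM, with an expected range of 30000 nM to 100000 nM.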

Compound 4, half-maximal cytotoxic concentration: > 50000 nM
Compound 4 was reported as a limit (the forecaster's own chance of this, stated with the estimate: 85%); the middle value sits exactly at the limit.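

In this assay, no step can be read among compound 1, compound 2, compound 3 and compound 4, as each value is a limit and not a number: the limit of > 50000 nM in this assay, at which 4 of the 4 values shown sit. The compounds shown leave open where their actual half-maximal cytotoxic concentrations lie and whether these differ.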